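The source may report more compounds than this note shows. Statements on the series, on what has been measured and on what is new or still open speak of the compounds shown alone.

Working notes on the series.

Compound 1 `COc1c(N2CCN(CC#N)C(C)C2)c(F)cc2c(=O)c(C(=O)O)cn(C3CC3)c12` and compound 2 `COC(=O)CN1CCN(c2c(F)cc3c(=O)c(C(=O)O)cn(C4CC4)c3c2OC)CC1C` are the two members with numbers in an ADME assay on Vero cells (Chlorocebus sabaeus) for cytotoxicity, read by MTT assay, with a stated time of 72 h; a higher number here means that more compound is tolerated, a lower number that less compound is tolerated. In this assay compound 1 gives 354 ug/mL, and compound 2 gives 500 ug/mL. For the measured compounds named here, the one measured step, a 1.4-fold higher number from compound 1 to compound 2 (0.15 log units; within the scatter), swaps a methoxycarbonyl for a cyano on a saturated chain carbon bound to an amine nitrogen in a ring and stays inside the scatter.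

Compound 3 `CCOC(=O)CCN1CCN(c2c(F)cc3c(=O)c(C(=O)O)cn(C4CC4)c3c2OC)CC1C` carries an (ethoxycarbonyl)methyl at the same place; in this assay compound 3 gives "not determined" (no result reported), so compound 3 stands without a number here.

Compound 4 `COc1c(N2CCN(C/C(C)=N/NC(C)=O)C(C)C2)c(F)cc2c(=O)c(C(=O)O)cn(C3CC3)c12` is yet to be measured. It differs from compound 3 as follows: a group of 7 heavy atoms (4 carbon, 2 nitrogen, 1 oxygen; no ring) in place of a group of 6 heavy atoms (4 carbon, 2 oxygen; no ring), on a saturated chain carbon bound to an amine nitrogen in a ring.

Going by the values given here, the only step that bears on this change is a 1.4-fold higher number from compound 1 to compound 2 (0.15 log units; within the scatter), a within-scatter move at the same place, and it involved groups of different composition from the one entering in compound 4. Nothing measured therefore points to a step beyond the scatter in this assay for compound 4. On that basis compound 4 is expected to give about 400 ug/mL in this assay, within a range from 200 ug/mL to 800 ug/mL.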

Compound 4, half-maximal cytotoxic concentration: 707 ug/mL
For compound 4 the middle estimate is 1.8-fold (0.25 log units) below the measured one, within the range that was stated.
By their numbers in this assay, from the lowest: compounds 1, 2 and 4 (each within the scatter of the next).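

At the saturated chain carbon bound to an amine nitrogen in a ring, the entering group of 7 heavy atoms, with its 1 hydrogen-bond donor and 2 double bonds outside aromatic rings, keeps this assay within the scatter, with a 1.4-fold higher number from compound 2 to compound 4 (0.15 log units; within the scatter) and a 2.0-fold higher number from compound 1 to compound 4 (0.30 log units; within the scatter) both printed as such. Cyano, methoxycarbonyl and this group therefore differ in size and composition without any step among compound 1, compound 2 and compound 4 leaving the scatter, a reading that holds for these compounds only. No measurement in hand explains why these numbers stay so close.

On these data alone, whether a primary amine, a carboxylic acid or a longer chain at this place would give a step beyond the scatter remains open. So does whether a group containing a ring would do so.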